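The source may report more compounds than this note shows. Statements on the series, on what has been measured and on what is new or still open speak of the compounds shown alone.

Compound 2 `CCn1c(C(=O)N(CCC#N)CCC#N)ccc1C(CC)(CC)c1ccc(OCC(O)C(C)(C)C)c(C)c1` is the weaker of the two compounds measured in an assay on HL-60 cells for agonist activity at vitamin D3 receptor (Homo sapiens), read by microscopy, with a stated time of 96 h (on this read-out lower numbers stand for an effect already at smaller amounts and higher numbers for an effect only at larger amounts of compound), so far, giving 97 nM, while compound 1 `CC[C@@H](C)[C@H](NC(=O)c1ccc(C(CC)(CC)c2ccc(OCC(O)C(C)(C)C)c(C)c2)n1CC)C(=O)OC` gives 26 nM. Compound 3 `CCn1c(C(=O)N(C)CC(=O)O)ccc1C(CC)(CC)c1ccc(OCC(O)C(C)(C)C)c(C)c1` differs from compound 2 only by a group of 6 heavy atoms (3 carbon, 1 nitrogen, 2 oxygen; no ring) in place of a group of 9 heavy atoms (6 carbon, 3 nitrogen; no ring), on a carbonyl carbon. Among the compounds with values here, the one step known at this position, a 3.7-fold higher number from compound 1 to compound 2 (0.57 log units; beyond the scatter), shows that changing the group on this carbonyl carbon shifts the read-out in this assay modestly. Compound 3 is therefore expected to move by a 1.6-fold lower number from compound 2 to compound 3 (0.21 log units; within the scatter), and its estimated value in this assay is 60 nM, within a range of 15 nM to 250 nM.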

Compound 3, half-maximal effective concentration: 740 nM
For compound 3 the middle estimate is 12-fold (1.09 log units) below the measured one, outside the stated range (above it).
By their numbers in this assay, from the lowest: compound 1; then compound 2; then compound 3.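

In this assay the group on this carbonyl carbon can move the number much further than the first step suggested: (carboxymethyl)(methyl)amino brings a 7.6-fold higher number from compound 2 to compound 3 (0.88 log units; beyond the scatter) and also a 28-fold higher number from compound 1 to compound 3 (1.45 log units; beyond the scatter). Of the three groups shown, it gives the highest number, and both steps lie beyond the scatter. No available data explain this shift.

The compounds shown leave open whether the shift follows the carboxylic acid itself, as each step changes the whole group at once. A dimethylamino group on the same carbonyl carbon would help separate the carboxylic acid from the rest of the group.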